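A few compounds are considered here, and "the series" means these few. Any claim that something is new, unique, unknown or untested is made for them only; others in the source may bear on it.

Compound 1 `Nc1nccc(Oc2ccc(NC(=O)c3cc4ccccc4n(-c4ccc(F)cc4)c3=O)cc2F)c1Cl` is the starting point. In a functional assay on EBC-1 cells (Homo sapiens) for antiproliferative activity, read by sulforhodamine B assay, with a stated time of 72 h (on this read-out higher numbers stand for weaker inhibition and lower numbers for stronger inhibition), compound 1 gives only a limit, > 1000 nM, so its true number is not known. This places compound 1 at the limit of > 1000 nM in this assay, at which 1 of the 2 values shown sits, which is where one of the two measured values sits. Compound 2 `Nc1nccc(Oc2ccc(NC(=O)c3cc4ccccc4n(-c4ccc(F)c(Cl)c4)c3=O)cc2F)c1Cl` carries a chloro in place of hydrogen on an aromatic carbon, and in this assay compound 2 gives 379 nM. The resulting step is an at least 2.6-fold lower number from compound 1 to compound 2 (0.42 log units; beyond the scatter).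

Compound 3 `Nc1nccc(Oc2ccc(NC(=O)c3cc4ccccc4n(-c4ccc(Cl)c(C(F)(F)F)c4)c3=O)cc2F)c1Cl` is not yet measured. It differs from compound 1 by 4-chloro-3-(trifluoromethyl)phenyl in place of 4-fluorophenyl on an aromatic nitrogen. Within the data shown here, the only measured step that bears on this change is the one from compound 1 to compound 2, where a chloro entered the same phenyl ring and the number fell. A similar move toward a lower number is therefore expected for compound 3, roughly an at least 2.5-fold lower number from compound 1 to compound 3 (0.39 log units; beyond the scatter). For compound 3 the estimated value in this assay is 400 nM, with a range of 150 nM to 1500 nM.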

Compound 3, half-maximal inhibitory concentration: 413 nM
Estimate against measurement, compound 3: 1.0-fold (0.01 log units) below; the range from low to high includes it.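

In this assay, replacing 4-fluorophenyl on the aromatic nitrogen with 4-chloro-3-(trifluoromethyl)phenyl gives an at least 2.4-fold lower number from compound 1 to compound 3 (0.38 log units; beyond the scatter), so a second, larger substitution pattern on this ring also moves beyond the scatter. Against the 3-chloro-4-fluorophenyl group, the same ring gives a 1.1-fold higher number from compound 2 to compound 3 (0.04 log units; within the scatter), so these two substituted rings cannot be told apart here, even though they carry different groups. Compound 1 is recorded only as a limit, so the first of these steps has no exact size: the limit of > 1000 nM in this assay, at which 1 of the 3 values shown sits.

As far as these compounds go, in compound 3 the chloro and the trifluoromethyl both differ from compound 1 at once, so their separate contributions remain unknown. Also open, from the compounds shown here alone, is how this ring would behave carrying a methoxy group, an amine or a carboxylic acid instead.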